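Methoxy in Place of Methyl: Compound 3 to Compound 4

The compounds below may be only part of what the source reports. "The series", "measured", "known", "first", "only" and "open" are said of these compounds alone.

Three compounds sharing one core were measured in a functional assay on the whole organism for inhibition, with Digitaria ciliaris as the target, with a stated time of 72 h, tested at 100 mg/L; a lower number here means less inhibition of growth, a higher number more inhibition of growth at the concentration tested. Compound 1 `Cc1cc(Cl)nc(NC(=S)NC(=O)c2c(-c3ccc(Cl)cc3Cl)noc2C)n1` gives 44.2%, compound 2 `CSc1cc(C)nc(NC(=S)NC(=O)c2c(-c3ccc(Cl)cc3Cl)noc2C)n1` gives 45.5%, and compound 3 `Cc1cc(C)nc(NC(=S)NC(=O)c2c(-c3ccc(Cl)cc3Cl)noc2C)n1` gives 61.4%, the highest of the three; its steps to both others lie beyond the scatter, so it is the most active of the set. The step of a number 17.2 percentage points higher from compound 1 to compound 3 (beyond the scatter) and the step of a number 15.9 percentage points higher from compound 2 to compound 3 (beyond the scatter) are both modest gains, whereas a number 1.3 percentage points higher from compound 1 to compound 2 (within the scatter) stays within the scatter.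

Compound 4 `COc1cc(OC)nc(NC(=S)NC(=O)c2c(-c3ccc(Cl)cc3Cl)noc2C)n1` differs from compound 3 in one place: 4,6-dimethoxypyrimidin-2-yl in place of 4,6-dimethylpyrimidin-2-yl on an amide-type nitrogen. Going by the values given here, none of the measured steps involves a methoxy group, so they bear on this change only indirectly: they show that exchanging the groups on this ring shifts inhibition by modest amounts, and that the methyl groups of compound 3 gave the highest number. Because a number 17.2 percentage points higher from compound 1 to compound 3 (beyond the scatter) and a number 15.9 percentage points higher from compound 2 to compound 3 (beyond the scatter) both favour methyl over the other groups tried, a modest fall is expected for compound 4, a step of a number 13.4 percentage points lower from compound 3 to compound 4 (beyond the scatter). Compound 4 is therefore estimated at 48%, with a range from 30% to 65%.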

Compound 4, percent growth inhibition at one concentration: 65.9%
For compound 4 the middle estimate is 17.9 percentage points below the measured one; the measured number lies above the stated range.
By their numbers in this assay, from the lowest: compounds 1 and 2 (each within the scatter of the next); then compounds 3 and 4 (each within the scatter of the next).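

In this assay, the 4,6-dimethoxypyrimidin-2-yl group on the amide-type nitrogen stays level with the 4,6-dimethylpyrimidin-2-yl group, with a number 4.5 percentage points higher from compound 3 to compound 4 (within the scatter), so methyl is no longer the only substituent shown to reach the upper level of inhibition. The methoxy compound also stands clear of the methylsulfanyl and chloro compounds, with a number 20.4 percentage points higher from compound 2 to compound 4 (beyond the scatter) and a number 21.7 percentage points higher from compound 1 to compound 4 (beyond the scatter), which divides the set into two levels: compounds 1 and 2, then compounds 3 and 4. No measurement at hand accounts for methoxy and methyl sharing the upper level.

From the compounds shown here alone, it remains open whether the 4-methoxy-6-methylpyrimidin-2-yl group, carrying one of each, would stay at that level. Going by these compounds, it is equally open whether a dimethylamino group or a longer chain such as ethoxy would rise above it.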